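The source may hold more compounds than are shown below. What is called first, only, known or untested is meant among the compounds shown, and "the series" means these compounds.

Measured compounds:
- compound 1, `CC(C(=O)NCc1cccc(Cl)c1)N1C(=O)CCC1=O`: "not determined" (no result reported) in a functional assay on the whole organism (strain Albino Swiss CD1) with Mus musculus as the target; on this read-out higher numbers stand for an effect only at larger amounts of compound and lower numbers for an effect already at smaller amounts
- compound 2, `CC(C(=O)NCc1cccc(F)c1)N1C(=O)CCC1=O`: "not determined" (no result reported) in this assay
- compound 3, `CCC(C(=O)NCc1cccc(Cl)c1)N1C(=O)CCC1=O`: 78.9 mg/kg

Of the three compounds for which this assay was run, only compound 3 yields a number; for compound 1 and compound 2 no result is given, so nothing can be said about how they compare. Compound 3 therefore stands alone on the numbers shown, and there is no step between measured compounds from which to read how a change at the aromatic ring plays out in this assay.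

The compound still to be measured is compound 4, `CCC(C(=O)NCc1cccc(F)c1)N1C(=O)CCC1=O`. It differs from compound 3 in one place: fluoro in place of chloro on an aromatic carbon. Everything else, the shared core and the ethyl side chain, is kept.

Going by the values given here, with no measured step of this kind available, the expectation can rest only on the single value of compound 3 and on the small size of the change. A step from compound 3 to compound 4 that stays within the usual scatter, or runs only slightly toward larger doses, is what is expected: a 1.3-fold higher number from compound 3 to compound 4 (0.10 log units; within the scatter). On that basis compound 4 is estimated to give 100 mg/kg in this assay, with a range from 40 mg/kg to 250 mg/kg.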

Compound 4, dose for half-maximal effect: 47.4 mg/kg
Compound 4: the middle estimate sits 2.1-fold (0.32 log units) above what was measured; the measured number falls inside the stated range.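

Going by these compounds alone, the step gives the first reading of this position in this assay: going from 3-chlorophenyl to 3-fluorophenyl, with the ethyl side chain and the shared core kept, comes out as a 1.7-fold lower number from compound 3 to compound 4 (0.22 log units; within the scatter). As this lies within the usual scatter, the two compounds cannot be told apart on this read-out, so the exchange of chloro for fluoro on this aromatic carbon, meta to a large group, is accommodated without a change that can be claimed, and a measurable dose remains. Nothing at hand bears on why the two numbers lie where they do.

What the compounds shown leave open is whether this position accepts anything other than these two halogens, since a methoxy group, a nitrile or an amine there, or a plain phenyl ring with no group at all, has no reading in this assay. From the compounds shown here alone, the side chain is equally open, as the ethyl group is the same in both compounds with numbers, and a single pair gives no reading of what a longer chain such as propyl would do to the dose.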